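The source may report more compounds than this note shows. Statements on the series, on what has been measured and on what is new or still open speak of the compounds shown alone.

Working notes on the series.

Compound 1, `Brc1ccc2ncnc(Nc3ccccc3)c2c1`, in a functional assay on HEK293 cells for antagonist activity at metabotropic glutamate receptor 5 (Rattus norvegicus), read by calcium flux (on this read-out lower numbers stand for stronger inhibition and higher numbers for weaker inhibition), gives > 10000 nM, which is a limit of the assay rather than a number. Compound 2, `Fc1cccc(Nc2ncnc3ccc(Br)cc23)c1`, in this assay gives 1970 nM. Among the measured compounds shown here, the one measured step, an at least 5.0-fold lower number from compound 1 to compound 2 (0.70 log units; beyond the scatter), is beyond the scatter, though its size is set against the limit of > 10000 nM in this assay, at which 1 of the 2 values shown sits, and is therefore only a lower bound. For the measured compounds named here, compound 2 thus holds the only number in the set, the remaining value being a limit.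

Compound 3 is `Brc1cccc(Nc2ncnc3ccc(Br)cc23)c1`. It differs from compound 2 by bromo in place of fluoro on an aromatic carbon, the new group sitting on an aromatic carbon of a six-membered aromatic ring of carbon only, meta to a large group. Going by the values given here, no measured step exchanges one halogen for another at this carbon; the step from compound 1 to compound 2 concerns fluoro replacing hydrogen, and bears on the present change only by showing that substitution at this carbon is tolerated and helps. The expected step of a 1.3-fold lower number from compound 2 to compound 3 (0.12 log units; within the scatter) is therefore within the scatter, with no direction claimed. Compound 3 is estimated at 1500 nM, in the range 400 nM to 6000 nM.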

Compound 3, half-maximal inhibitory concentration: 174 nM
Beside the measured number, compound 3's estimate is 8.6-fold (0.94 log units) above it; measured number outside the range, below it.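

The earlier compounds shown here showed only that fluoro on this aromatic carbon, meta to a large group, does better than hydrogen; they did not show whether the identity of the halogen matters. In this assay it matters a great deal: exchanging one halogen atom for another, with no ring, donor, acceptor or charge entering or leaving, gives an 11-fold lower number from compound 2 to compound 3 (1.05 log units; beyond the scatter), so the gain at this carbon is not exhausted by fluoro. Measured against the unsubstituted compound, bromo gives an at least 57-fold lower number from compound 1 to compound 3 (1.75 log units; beyond the scatter), a size that is only a lower bound, as it is set against a limit of the assay: the limit of > 10000 nM in this assay, at which 1 of the 3 values shown sits.

From the compounds shown here alone, the order hydrogen, fluoro, bromo rests on these three compounds alone, and it remains open whether chloro, iodo, methyl, methoxy or trifluoromethyl at this carbon would continue it or break it. Also open, going by these compounds, is whether the bromo on the shared core contributes to the result, which only its replacement by hydrogen, chloro or an amine could tell, and whether the gain from bromo holds at other carbons of the same ring.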